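The source may report more compounds than this note shows. Statements on the series, on what has been measured and on what is new or still open speak of the compounds shown alone.

For the measured compounds named here, in an ADME assay on cells (Peritoneal macrophage, Mus musculus) for cytotoxicity, read by MTT assay, with a stated time of 24 h (on this read-out lower numbers stand for higher toxicity in this test and higher numbers for lower toxicity in this test), two compounds sharing one core have numbers so far. Compound 1 `CC(C)(C)c1ccc(N/C(=N\C(=O)c2ccccc2)NCc2ccccc2)cc1` gives 1120000 nM, and compound 2 `Cc1ccc(N/C(=N\C(=O)c2ccccc2)NCc2ccccc2)cc1` gives 876000 nM. Going by the values given here, compound 2 therefore stands within the scatter of the only other number available, and the pair shows no order.

The next compound is compound 3 `COc1ccc(N/C(=N\C(=O)c2ccccc2)NCc2ccccc2)cc1`, which has methoxy in place of methyl on an aromatic carbon, para to a large group: methoxy in place of methyl on an aromatic carbon. Its side of the molecule thus changes from 4-methylphenyl to 4-methoxyphenyl, while the rest of the core stays as it is.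

Among the compounds with values here, only one measured step bears on this change: a 1.3-fold lower number from compound 1 to compound 2 (0.11 log units; within the scatter), with methyl in place of tert-butyl on an aromatic carbon. Within the data shown here, that exchange stayed within the scatter, but no measured step shows methoxy entering, so the evidence is indirect. No shift beyond the scatter is therefore expected in this assay, and the estimated move is a 1.0-fold higher number from compound 2 to compound 3 (0.01 log units; within the scatter). For compound 3 the expected value is 900000 nM, with an estimated range from 420000 nM to 1800000 nM.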

Compound 3, half-maximal cytotoxic concentration: 837000 nM
The estimate for compound 3 lay 1.1-fold (0.03 log units) above the measured number, and the stated range covers the measured number.
By their numbers in this assay, from the lowest: compounds 3, 2 and 1 (each within the scatter of the next).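

In this assay, methoxy on this aromatic carbon, para to a large group, stays within the scatter of methyl (a 1.0-fold lower number from compound 2 to compound 3 (0.02 log units; within the scatter)) and of tert-butyl (a 1.3-fold lower number from compound 1 to compound 3 (0.13 log units; within the scatter)). The earlier compounds shown here carried only carbon groups at this position, while compound 3 places an oxygen there and adds 1 hydrogen-bond acceptor, and the three numbers still cannot be put in any order. Thus, among these three compounds, neither the exchange of one carbon group for another nor the entry of this oxygen-bearing group gives a shift beyond the scatter, and nothing available offers an explanation for this result.

What the compounds shown leave open is whether an amine, a carboxylic acid or a longer chain at this same position would move the number beyond the scatter, or whether this position tolerates such groups as it does the three seen here. Going by these compounds, all three compounds also keep the rest of the shared core unchanged, so the effect of a change elsewhere in the molecule on this read-out remains unknown.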